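Halogen swap on the exocyclic chain: compound 3 to compound 4

The compounds below may be only part of what the source reports. "The series", "measured", "known", "first", "only" and "open" are said of these compounds alone.

Measured so far:
compound 1 `CCCCC1=C(Br)/C(=C/Br)OC1=O`: > 20 ug/mL
compound 2 `CCC[C@@H](O)C1=C(Br)/C(=C/I)OC1=O`: 4.1 ug/mL
compound 3 `CCC[C@@H](O)C1=C(Br)/C(=C/Br)OC1=O`: 3.4 ug/mL

In a functional assay on KB cells (Homo sapiens) for cytotoxicity (a lower number here means that less compound is needed, a higher number that more compound is needed for the effect), compound 3 gives the lowest of the two numbers, and the nearest neighbour sits at a 1.2-fold lower number from compound 2 to compound 3 (0.08 log units; within the scatter). For compound 1 the assay reports only a limit, > 20 ug/mL (the limit of > 20 ug/mL in this assay, at which 1 of the 3 values shown sits). Measured against that limit, the step is an at least 5.8-fold lower number from compound 1 to compound 3 (0.76 log units; beyond the scatter), which is at least modest.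

Compound 4 `CCC[C@@H](O)C1=C(Br)/C(=C/Cl)OC1=O` is not yet measured. It differs from compound 3 by chloro in place of bromo on a double-bonded chain carbon bound to a double-bonded ring carbon. For the measured compounds named here, the one measured step that bears on this place is a 1.2-fold lower number from compound 2 to compound 3 (0.08 log units; within the scatter), a halogen swap that stayed within the scatter. On that basis no change beyond the scatter is expected, and the estimated step is a 1.2-fold higher number from compound 3 to compound 4 (0.09 log units; within the scatter). For compound 4 the estimate in this assay is 4.2 ug/mL, expected to fall between 2 ug/mL and 9 ug/mL.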

Compound 4, concentration for half-maximal effect: 1.2 ug/mL
Estimate against measurement, compound 4: 3.5-fold (0.54 log units) above; measured number below the stated range.
By their numbers in this assay, from the lowest: compound 4; then compounds 3 and 2 (each within the scatter of the next). At a limit, above all of these: compound 1.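

In this assay, the halogen on a double-bonded chain carbon bound to a double-bonded ring carbon does affect the number, with chloro giving a 2.8-fold lower number from compound 3 to compound 4 (0.45 log units; beyond the scatter) and a 3.4-fold lower number from compound 2 to compound 4 (0.53 log units; beyond the scatter). The earlier bromo and iodo pair stayed within the scatter, so among these three halogens only chloro stands apart. Nothing measured here accounts for this difference.

Open, on these data alone, is whether fluoro or a nitrile at this place would lower the number further, and whether chloro has the same effect on the butyl chain without the hydroxy of compound 1.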